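Series notes: phenyl for allyl on the ring nitrogen

A few compounds are considered here, and "the series" means these few. Any claim that something is new, unique, unknown or untested is made for them only; others in the source may bear on it.

Measured so far:
compound 1 `C=CCn1c(SCC(=O)c2ccccc2)nnc1-c1ccc(OC)cc1` — 63%
compound 2 `C=CCn1c(SC/C(=N/O)c2ccccc2)nnc1-c1cc(OC)c(OC)c(OC)c1` — 70%
compound 3 `COc1ccc(-c2nnc(SCC(=O)c3ccccc3)n2-c2ccccc2)cc1` — 58%

All three were run in a functional assay on the whole organism (strain albino) for inhibition, with Rattus norvegicus as the target, read by paw edema, with a stated time of 3 h, at a dose of 0.28 mmol/kg by the oral route; a higher number here means more inhibition at the dose given (going by the name of the read-out), a lower number less inhibition. Compound 1 gives 63%, compound 2 gives 70% and compound 3 gives 58%. Compound 1 and compound 3 differ in one place, (phenyl in place of allyl on an aromatic nitrogen), and the step is a number 5 percentage points lower from compound 1 to compound 3 (within the scatter). The cores of compound 1 and compound 2 are not the same; the difference between the two cores is not broken down here, and the two values differ within the scatter.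

Compound 4 `COc1cc(-c2nnc(SC/C(=N/O)c3ccccc3)n2-c2ccccc2)cc(OC)c1OC` is not yet measured in this assay. It differs from compound 2 by phenyl in place of allyl on an aromatic nitrogen. For the measured compounds named here, this is the same kind of change as the one from compound 1 to compound 3: both replace allyl with phenyl on an aromatic nitrogen of the five-membered aromatic ring with three nitrogen, though in compound 4 the ring nitrogen is next to two ring atoms that each bear a large group, while in compound 3 it is next to the ring atom that bears a 4-methoxyphenyl group and next to the ring atom that bears a large group. Because the earlier step is a number 5 percentage points lower from compound 1 to compound 3 (within the scatter), a step of similar size is expected here, a number 5 percentage points lower from compound 2 to compound 4 (within the scatter), on the sole basis of that one pair. Compound 4 is therefore estimated at 65%, with a range of 52% to 78%.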

Compound 4, a percentage reported as inhibition, in the whole organism at one dose (the size of the read-out at that dose, not a potency): 64%
Compound 4: the middle estimate sits 1 percentage points above what was measured; the range from low to high includes it.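

In this assay, phenyl in place of allyl on an aromatic nitrogen gives a number 6 percentage points lower from compound 2 to compound 4 (within the scatter). Set beside the earlier step, the change carries from one core to the other with no difference that can be told apart: the same change on two cores in this assay, a number 5 percentage points lower (within the scatter) from compound 1 to compound 3 and a number 6 percentage points lower (within the scatter) from compound 2 to compound 4, 1 percentage points apart, within the scatter of two such steps. This agreement rests on two pairs only, and as neither step stands clear of the scatter, it shows that the swap leaves no distinct mark on these two cores, not that the same would hold on a third core, and a read-out at one dose and one time says nothing of potency.

Open, as far as these compounds go, is what other groups on that ring nitrogen would give, such as a longer chain, a benzyl group or a chain ending in an amine. Also open, from the compounds shown here alone, is how the ketone and oxime side chains or the methoxy groups each contribute, and whether the step would stay the same on a core bearing a carboxylic acid.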